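This account rests on a few compounds, and the source may have more. Where it says the series, first, only, none or still open, it means among the compounds named here.

Compound 1 `CCC(C)(C)Cc1c[nH]c(CCc2ccc(-n3ccnn3)cc2)n1` is the reference point of this short series. Within the data shown here, in a functional assay on HEK293 cells for agonist activity at Bombesin receptor subtype-3 (Mus musculus), read by luminescence and calcium flux, with a stated time of 10 min (on this read-out higher numbers stand for an effect only at larger amounts of compound and lower numbers for an effect already at smaller amounts), compound 1 gives 111 nM, the lowest of the two numbers so far, though its nearest neighbour, compound 2 `CCC(C)(C)Cc1c[nH]c(CCc2ccc(-n3cncn3)cc2)n1`, sits within the scatter: in this assay compound 2 gives 121 nM, and the step of a 1.1-fold higher number from compound 1 to compound 2 (0.04 log units; within the scatter) is too small to count as a change.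

The next compound, compound 3 `CCC(C)(C)Cc1c[nH]c(CCc2ccc(-c3ccns3)cc2)n1`, departs from compound 1 by 1,2-thiazol-5-yl in place of 1H-1,2,3-triazol-1-yl on an aromatic carbon. Among the measured compounds shown here, the one measured step that bears on this is the exchange of one five-membered aromatic ring for another at the same place, a 1.1-fold higher number from compound 1 to compound 2 (0.04 log units; within the scatter), which lay within the scatter. On that basis the step is expected to be small, a 1.4-fold higher number from compound 1 to compound 3 (0.13 log units; within the scatter), with wider uncertainty because the entering ring differs more from the leaving one than the earlier pair did. Compound 3 is therefore estimated at 150 nM, in a range from 60 nM to 400 nM.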

Compound 3, half-maximal effective concentration: 103 nM
The estimate for compound 3 lay 1.5-fold (0.16 log units) above the measured number; measured number inside the range.
By their numbers in this assay, from the lowest: compounds 3, 1 and 2 (each within the scatter of the next).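

The exchange reaches further than the earlier pair of triazoles: a 1,2-thiazol-5-yl ring, one five-membered aromatic ring with 2 hetero atoms including a sulfur, replaces a ring with 3 hetero atoms, all nitrogen. Even so, this assay shows a 1.1-fold lower number from compound 1 to compound 3 (0.03 log units; within the scatter) and a 1.2-fold lower number from compound 2 to compound 3 (0.07 log units; within the scatter), both within the scatter. At this place, para to a large group, all three five-membered aromatic rings therefore give numbers that cannot be told apart, so neither the nitrogen count nor the entry of sulfur shows any effect here. Nothing at hand offers an explanation for this flat result.

Every group shown here is a five-membered aromatic ring, so the response to a carboxylic acid, an amine or a six-membered ring such as pyridine at this place remains open. Whether any group here can move the number beyond the scatter also remains unanswered.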